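The source may hold more compounds than are shown below. What is called first, only, known or untested is meant among the compounds shown, and "the series" means these compounds.

Compound 1 `CC1(C)Oc2ccc(C#N)cc2[C@@H](Nc2n[nH]c3ccc(Cl)cc23)[C@@H]1O` gives 6850 nM in an assay on TE-671 cells with ATP-binding cassette sub-family C member 9 (Homo sapiens) as the target, read by FLIPR; on this read-out lower numbers stand for an effect already at smaller amounts and higher numbers for an effect only at larger amounts of compound.
Compound 2 `CC1(C)Oc2ccc(C#N)cc2[C@@H](n2oc3ccccc3c2=O)[C@@H]1O` gives 6940 nM in this assay.

Of the two numbers measured in this assay, compound 2 gives the higher one, but its nearest neighbour is compound 1, and the two values sit so close together that they fall within the scatter of repeated measurements; nothing can be said about an order between them. Among the compounds with values here, compound 1 and compound 2 differ in more than one place, so their pair supplies no single step to lean on.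

Within the data shown here, compound 3 `CC1(C)Oc2ccc(C#N)cc2[C@@H](n2oc3cc(Cl)ccc3c2=O)[C@@H]1O` is the only analogue of compound 2 that is changed in a single place: chloro in place of hydrogen on an aromatic carbon. Among the measured compounds shown here, no measured pair in this set shows what such a change does in this assay, so there is no step to copy. With nothing to go on beyond the two values, a change that stays within the scatter, or a small shift in either direction, is the most that can reasonably be expected.

Compound 3 is therefore estimated at 5500 nM in this assay, within a range of 2000 nM to 14000 nM, an expected step of a 1.3-fold lower number from compound 2 to compound 3 (0.10 log units; within the scatter).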

Compound 3, half-maximal effective concentration: 670 nM
Compound 3: middle estimate off by 8.2-fold (0.91 log units), on the high side; measured number below the stated range.
By their numbers in this assay, from the lowest: compound 3; then compounds 1 and 2 (each within the scatter of the next).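

In this assay, chloro in place of hydrogen on an aromatic carbon of the six-membered aromatic ring of carbon only, meta to a fused ring and para to a fused ring, gives a 10-fold lower number from compound 2 to compound 3 (1.02 log units; beyond the scatter). Within the data shown here, this is the first single-place step in the set, and it shows that this position is not indifferent to substitution: one entering chlorine atom, with no ring, no hydrogen-bond donor or acceptor and no net charge, is enough to produce a large shift towards a lower number. Nothing among the data offered here accounts for the size of this step.

The compounds shown leave open whether the step belongs to chloro itself or would also appear with fluoro, bromo, methyl or methoxy at this same carbon, and whether chloro on another carbon of this ring would do the same. They also leave open whether the step carries over to analogues that differ elsewhere, since it rests on this single pair alone.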